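A fluorinated amide swap on the shared core

The source may hold more compounds than are shown below. What is called first, only, known or untested is meant among the compounds shown, and "the series" means these compounds.

Compound 1 `CC(=O)Nc1ccc(Cc2noc(CCC(=O)Nc3ccccc3)n2)cc1` and compound 2 `CC(=O)Nc1ccc(Cc2noc(CCC(=O)Nc3ccc(F)cc3F)n2)cc1` share the same core and differ only in the aryl group on the amide-type nitrogen. In a functional assay on the whole organism (strain C57BL/6) for inhibition, with Mus musculus as the target, read by paw edema, with stated times of 1 h and 4 h, at a dose of 100 mg/kg by the oral route (on this read-out lower numbers stand for less inhibition and higher numbers for more inhibition at the one dose given (going by the name of the read-out)), compound 1 gives 34.2%, and in this assay compound 2 gives 52.1%. Among the measured compounds shown here, the single step recorded between them, a number 17.9 percentage points higher from compound 1 to compound 2 (beyond the scatter), places compound 2 as the higher of the two measured compounds, with compound 1 as its nearest neighbour.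

Compound 3 `CC(=O)Nc1ccc(Cc2noc(CCC(=O)Nc3ccc(C(F)(F)F)cc3)n2)cc1` is the next point. The change from compound 2 is 4-(trifluoromethyl)phenyl in place of 2,4-difluorophenyl on an amide-type nitrogen. For the measured compounds named here, no measured pair tells what happens when one fluorinated aryl group is exchanged for another on this nitrogen; the only step on record concerns the introduction of fluorine onto plain phenyl, from compound 1 to compound 2, and it was modest. Since compound 3 keeps a fluorine-bearing aryl group, the step of a number 4.1 percentage points lower from compound 2 to compound 3 (within the scatter) is expected to stay within the scatter, in either direction. Compound 3 is therefore estimated at 48%, with a range from 32% to 64%.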

Compound 3, a percentage reported as inhibition, in the whole organism at one dose (the size of the read-out at that dose, not a potency): 37%
For compound 3 the middle estimate is 11 percentage points above the measured one, within the range that was stated.
By their numbers in this assay, from the lowest: compounds 1 and 3 (each within the scatter of the next); then compound 2.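

On this amide-type nitrogen, the presence of fluorine on the aryl group does not settle the read-out: in this assay, exchanging one fluorinated aryl group for another gives a number 15.1 percentage points lower from compound 2 to compound 3 (beyond the scatter), so the choice between 2,4-difluorophenyl and 4-(trifluoromethyl)phenyl counts here. Measured against plain phenyl, trifluoromethyl in place of hydrogen on an aromatic carbon gives a number 2.8 percentage points higher from compound 1 to compound 3 (within the scatter), which leaves compound 1 and compound 3 indistinguishable in this read-out, and among these three compounds only compound 2 stands apart from both others. Nothing at hand accounts for this difference between the two fluorinated aryl groups.

The compounds shown leave open whether the gap between compound 2 and compound 3 follows the number of fluorine atoms, where they sit on the ring, or the trifluoromethyl group as such. They also leave open how a phenyl ring carrying a single fluorine, a chlorine or a methoxy group would compare with compound 2 on this nitrogen.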